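Hydroxymethyl for hydroxy in a series near the limit

This account rests on a few compounds, and the source may have more. Where it says the series, first, only, none or still open, it means among the compounds named here.

In a functional assay on K562 cells (Homo sapiens) for antiproliferative activity (a higher number here means a weaker inhibitor, a lower number a stronger inhibitor), compound 1 (`Nc1n[nH]c(N)c1/N=N/c1ccccc1[N+](=O)[O-]`) gives 100000 nM. Compound 2 (`Nc1n[nH]c(N)c1/N=N/c1ccccc1O`) reads > 100000 nM, which is a limit of the assay and not a number. Within the data shown here, the one measured step is a number no lower from compound 1 to compound 2 (the limit leaves the size open), with hydroxy in place of nitro on an aromatic carbon, and its size cannot be read. Among the measured compounds shown here, the series so far shows (the limit of > 100000 nM in this assay, at which 1 of the 2 values shown sits).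

Compound 3 (`Nc1n[nH]c(N)c1/N=N/c1ccccc1CO`) carries hydroxymethyl in place of hydroxy on an aromatic carbon. For the measured compounds named here, no measured step covers this change directly, so the only guide is the weak standing of the two measured compounds, and no marked gain in this assay is expected. The expected step is a number no higher from compound 2 to compound 3 (the limit leaves the size open), with no clear change estimated. For compound 3 the estimated value is 100000 nM, with an expected range of 40000 nM to 200000 nM.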

Compound 3, half-maximal inhibitory concentration: > 100000 nM
Compound 3 ended at the assay's limit (the forecaster's own chance of this, stated with the estimate: 70%); the middle value sits exactly at the limit.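

Hydroxymethyl, like hydroxy, leaves the series at the limit of this assay, so neither group on this aromatic carbon, ortho to a group of 9 heavy atoms, yields a readable value. Compound 3 reads > 100000 nM, a limit of the assay and not a number. The step is a number no lower from compound 1 to compound 3 (the limit leaves the size open) with hydroxymethyl in place of nitro on an aromatic carbon. Neither its size nor that of the step that reaches compound 3 from compound 2 can be read, and the series is now mostly bounded by this limit: the limit of > 100000 nM in this assay, at which 2 of the 3 values shown sit.

As far as these compounds go, how far compound 2 and compound 3 lie from each other remains open, as does the size of any loss from the nitro group of compound 1. Also open, from the compounds shown here alone, is whether an amine, a carboxylic acid or a longer chain on this carbon would bring a value inside the readable range of this assay.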